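From thiophen-2-yl to thiophen-3-yl on a shared core

The source may report more compounds than this note shows. Statements on the series, on what has been measured and on what is new or still open speak of the compounds shown alone.

Of the compounds shown here, three on one shared core have been tested in a functional assay on HeLa S3 cells (Homo sapiens) for antiproliferative activity, read by XTT assay, with a stated time of 72 h; a higher number here means a weaker inhibitor, a lower number a stronger inhibitor. Compound 1 `CNc1ncnc2c1c(-c1ccco1)cn2[C@@H]1O[C@H](CO)[C@@H](O)[C@H]1O`, carrying furan-2-yl, gives 5000 nM. Compound 2 `CNc1ncnc2c1c(-c1ccoc1)cn2[C@@H]1O[C@H](CO)[C@@H](O)[C@H]1O`, carrying furan-3-yl, reads > 20000 nM, which is a limit of the assay and not a number. Compound 3 `CNc1ncnc2c1c(-c1cccs1)cn2[C@@H]1O[C@H](CO)[C@@H](O)[C@H]1O`, carrying thiophen-2-yl, reads > 20000 nM, also a limit. Compound 3 thus stands at the limit of > 20000 nM in this assay, at which 2 of the 3 values shown sit.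

Compound 4 `CNc1ncnc2c1c(-c1ccsc1)cn2[C@@H]1O[C@H](CO)[C@@H](O)[C@H]1O` has not yet been measured. Its difference is thiophen-3-yl in place of thiophen-2-yl on an aromatic carbon.

The closest parallel is the furan pair, which shows an at least 4.0-fold higher number from compound 1 to compound 2 (0.60 log units; beyond the scatter) with furan-3-yl in place of furan-2-yl. The exchange of furan-2-yl for thiophen-2-yl shows an at least 4.0-fold higher number from compound 1 to compound 3 (0.60 log units; beyond the scatter). Both steps are beyond the scatter, though each gives only a minimum size. The remaining comparison offers a step that the two limits leave unreadable from compound 2 to compound 3. Going by an at least 4.0-fold higher number from compound 1 to compound 2 (0.60 log units; beyond the scatter), no gain is expected from this change, and no readable step beyond the scatter towards a lower number is anticipated in this assay. The expected outcome is a number no higher from compound 3 to compound 4 (the limit leaves the size open). For compound 4 the estimate is 20000 nM, with an expected range from 7000 nM to 40000 nM.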

Compound 4, half-maximal inhibitory concentration: > 20000 nM
Compound 4 was reported as a limit; the forecaster's own chance of this, stated with the estimate: 75%; the middle value lies on the limit itself.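

In this assay compound 4 also ends at a limit of the assay, so thiophen-3-yl at this position, on an aromatic carbon two ring bonds from the ring nitrogen, gives no readable value, and the move from thiophen-2-yl to thiophen-3-yl brings no activity into range: the limit of > 20000 nM in this assay, at which 3 of the 4 values shown sit.

Furan-2-yl in compound 1 now stands apart from all three other groups tested at this position, with an at least 4.0-fold higher number from compound 1 to compound 4 (0.60 log units; beyond the scatter), a minimum size only and the third such step away from that group. The steps that link compound 4 to compound 2 and to compound 3 cannot be read, as both ends of each are limits.

From the compounds shown here alone, how far compound 2, compound 3 and compound 4 lie from one another past the limit therefore stays open, and so does any real difference between the two thiophene attachments. Going by these compounds, it also remains open whether any other group at this position, such as a phenyl ring, a pyridine ring or a plain methyl group, would give a readable value in this assay.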